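The compounds below may be only part of what the source reports. "The series", "measured", "known", "first", "only" and "open" are said of these compounds alone.

Compound 1 `Cc1ccc(CC(CNC(=O)C2(c3ccc(NS(C)(=O)=O)cc3)CC2)COC(=O)C(C)(C)C)cc1C` gives 396 nM in an assay on CHO cells for displacement of a labelled ligand from transient receptor potential cation channel subfamily V member 1 (Rattus norvegicus) (on this read-out higher numbers stand for weaker inhibition and lower numbers for stronger inhibition), the highest of the three numbers recorded so far. Compound 2 `COc1cc(C(C)(C)C(=O)NCC(COC(=O)C(C)(C)C)Cc2ccc(C)c(C)c2)ccc1NS(C)(=O)=O` gives 153 nM in this assay, and compound 3 `CC(C(=O)NCC(COC(=O)C(C)(C)C)Cc1ccc(C(C)(C)C)cc1)c1ccc(NS(C)(=O)=O)cc1` gives 55 nM; each of these lies beyond the scatter from compound 1. Compound 4 `COc1cc(C2(C(=O)NCC(COC(=O)C(C)(C)C)Cc3ccc(C)c(C)c3)CC2)ccc1NS(C)(=O)=O` has not yet been measured. It differs from compound 1 in one place: methoxy in place of hydrogen on an aromatic carbon, the new group sitting ortho to a methanesulfonamido group and meta to a large group. Going by the values given here, compound 2 carries the same methoxy group together with a different linker, so no single step isolates this change. The change is expected to lower this assay only modestly, by a 2.0-fold lower number from compound 1 to compound 4 (0.30 log units; within the scatter). Compound 4 is accordingly estimated at 200 nM, within a range of 80 nM to 500 nM.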

Compound 4, inhibition constant: 239 nM
Compound 4: the middle estimate sits 1.2-fold (0.08 log units) below what was measured; the measured number falls inside the stated range.
By their numbers in this assay, from the lowest: compound 3; then compounds 2, 4 and 1 (each within the scatter of the next, the first and the last beyond it).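

Going by these compounds alone, the methoxy change can now be read on its own, since it is the only difference in the step of a 1.7-fold lower number from compound 1 to compound 4 (0.22 log units; within the scatter) in this assay. At this place, ortho to a methanesulfonamido group and meta to a large group, replacing hydrogen with methoxy therefore leaves the number within the scatter. Nothing available gives a reason for this result.

Going by these compounds, whether ethoxy, a hydroxyl group or fluorine at this place would also stay within the scatter remains open. So does whether methoxy would do the same on the linker of compound 3.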